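This account rests on a few compounds, and the source may have more. Where it says the series, first, only, none or still open, it means among the compounds named here.

Of the compounds shown here, three of one shared core have been measured in an assay on isolated protein for agonist activity at Bile acid receptor (Homo sapiens), read by TR-FRET, with a stated time of 3 h, in the absence of a further agent; a higher number here means that more compound is needed for the effect, a lower number that less compound is needed. Compound 1 `CCCCCOc1cccc(C(=O)Nc2cccc(C(=O)O)c2)c1` gives 2540 nM, compound 2 `CC(C)COc1cccc(C(=O)Nc2cccc(C(=O)O)c2)c1` gives 1130 nM, and compound 3 `O=C(O)c1cccc(NC(=O)c2cccc(OCc3ccccc3)c2)c1` gives 1160 nM. The change a 2.2-fold lower number from compound 1 to compound 2 (0.35 log units; beyond the scatter) and the change a 2.2-fold lower number from compound 1 to compound 3 (0.34 log units; beyond the scatter) both move the number beyond the scatter, while a 1.0-fold higher number from compound 2 to compound 3 (0.01 log units; within the scatter) stays within it. Compound 3 therefore stands with compound 2 on the numbers shown, and apart from compound 1 only.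

Compound 4 `Cc1ccccc1-c1cccc(C(=O)Nc2cccc(C(=O)O)c2)c1` has not yet been measured in this assay. It differs from compound 3 in that (2-methylphenyl in place of benzyloxy on an aromatic carbon). The three measured steps all vary only the group on the ether oxygen and keep that oxygen; none removes it or joins a ring directly to the aromatic carbon, so they bear on this change only loosely. They show that the group at this position shifts the number in this assay by modest amounts. Compound 4 is therefore expected to show a step of a 1.3-fold higher number from compound 3 to compound 4 (0.11 log units; within the scatter), with a wide margin. The number estimated for compound 4 is 1500 nM, likely between 400 nM and 6000 nM.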

Compound 4, half-maximal effective concentration: 68 nM
Beside the measured number, compound 4's estimate is 22-fold (1.34 log units) above it; the measured number lies below the stated range.
By their numbers in this assay, from the lowest: compound 4; then compounds 2 and 3 (each within the scatter of the next); then compound 1.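

In this assay, a 2-methylphenyl on the aromatic carbon gives steps far larger than any seen among the three ether-linked groups (a 17-fold lower number from compound 3 to compound 4 (1.23 log units; beyond the scatter); a 17-fold lower number from compound 2 to compound 4 (1.22 log units; beyond the scatter); a 37-fold lower number from compound 1 to compound 4 (1.57 log units; beyond the scatter)). The earlier steps shown here had changed only the group on the ether oxygen and shifted the number modestly or not beyond the scatter, whereas this change removes that oxygen and shows that the position can support a much larger shift. Nothing shown here explains the size of these steps.

The compounds shown leave open whether the step follows from losing the oxygen, from the directly attached ring, or from its methyl group, since all three differ together in compound 4. A plain phenyl, a 2-chlorophenyl or a 2-methoxyphenyl at this place would begin to separate these.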